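The source may hold more compounds than are shown below. What is called first, only, known or untested is meant among the compounds shown, and "the series" means these compounds.

Measured compounds:
compound 1 `FC(F)(F)c1c(CN2CCCC(c3ccccc3)C2)ccn2c(CC3CC3)nnc12`: 65 nM
compound 2 `CC1(c2ccccc2)CCCN(Cc2ccn3c(CC4CC4)nnc3c2C(F)(F)F)C1`: 2.6 nM
compound 3 `FC(F)(F)c1c(CN2CCC(c3ccccc3Cl)CC2)ccn2c(CC3CC3)nnc12`: 13.5 nM

In an assay on CHO cells for positive allosteric modulation of metabotropic glutamate receptor 2 (Homo sapiens), read by scintillation counting, with a stated time of 30 min (a lower number here means that less compound is needed, a higher number that more compound is needed for the effect), compound 3 stands second highest of the three numbers; compound 1 gives a higher number and compound 2 a lower one, and both gaps lie beyond the scatter. Going by the values given here, the only step between two compounds that differ in one place is a 25-fold lower number from compound 1 to compound 2 (1.40 log units; beyond the scatter), a change on a saturated ring carbon of the six-membered non-aromatic ring with 1 nitrogen.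

Compound 4 `Fc1ccc(OC2CCN(Cc3ccn4c(CC5CC5)nnc4c3C(F)(F)F)CC2)c(F)c1` differs from compound 3 by 2,4-difluorophenoxy in place of 2-chlorophenyl on a saturated ring carbon. Among the compounds with values here, no measured step covers an exchange of the aromatic group on that ring carbon for an aryl ether, so the single available step bears on it only by place, not by kind: it shows that a change on this ring can move the number far in this assay, but it gives no direction for the present change. Within the data shown here, with no closer precedent, the expectation rests on compound 3 alone, and a step of moderate size in either direction cannot be ruled out.

For compound 4 the value in this assay is estimated at 25 nM, with a range from 6 nM to 100 nM. This estimate means an expected 1.9-fold higher number from compound 3 to compound 4 (0.27 log units; within the scatter), a step that may well stay within the scatter.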

Compound 4, half-maximal effective concentration: 57 nM
The estimate for compound 4 lay 2.3-fold (0.36 log units) below the measured number, and the stated range covers the measured number.
By their numbers in this assay, from the lowest: compound 2; then compound 3; then compounds 4 and 1 (each within the scatter of the next).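

In this assay, 2,4-difluorophenoxy in place of 2-chlorophenyl, on the saturated ring carbon three ring bonds from the ring nitrogen, gives a 4.2-fold higher number from compound 3 to compound 4 (0.63 log units; beyond the scatter). Going by these compounds alone, this is the first reading of an exchange of the large group at this ring carbon: the number responds beyond the scatter, and it responds upward, so this aryl ether is a modest loss against the directly attached 2-chlorophenyl. The exchange brings in an oxygen, swaps chlorine for fluorine and adds a hydrogen-bond acceptor all at once, the single step cannot apportion its size among these, and no measurement available here accounts for it.

Going by these compounds, whether 2-chlorophenoxy or 2,4-difluorophenyl on this ring carbon would stand nearer compound 3 or compound 4 remains open, and with it the separate shares of the oxygen and of the halogens. Also open, on these data alone, is whether a methyl on this ring carbon, alongside the large group, would give a drop of the kind seen in a 25-fold lower number from compound 1 to compound 2 (1.40 log units; beyond the scatter).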